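Swapping cyclohexyl for trifluoromethyl on the shared core

The source may hold more compounds than are shown below. What is called first, only, known or untested is meant among the compounds shown, and "the series" means these compounds.

Of the compounds shown here, two built on the same core have been measured so far. Compound 1 `Cn1nc(CN2CCCC2)nc1-c1ccc(C2CCCCC2)cc1` carries a cyclohexyl group on its outer aromatic ring; in an assay on membranes from Jurkat cells for displacement of a labelled ligand from Sigma non-opioid intracellular receptor 1 (Homo sapiens), read by scintillation counting, with a stated time of 2 h (a higher number here means a weaker inhibitor, a lower number a stronger inhibitor), compound 1 gives 20 nM. Compound 2 `Cn1nc(CN2CCCC2)nc1-c1ccc(Cl)c(Cl)c1` has two chlorine atoms on that ring instead, and in this assay compound 2 gives 22 nM. Compound 1 shows the lower of the two numbers, but the gap to compound 2 lies within the usual scatter, so the two cannot be told apart.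

Compound 3 `Cn1nc(CN2CCCC2)nc1-c1ccc(C(F)(F)F)cc1` has not yet been measured. It differs from compound 1 in one place: trifluoromethyl in place of cyclohexyl on an aromatic carbon. For the measured compounds named here, no measured pair shows this exact change, so its effect is not known. Since compound 1 and compound 2, which carry quite different groups on this ring, give values within the scatter of each other, only a small step is expected from compound 1 to compound 3, probably towards a somewhat higher number, estimated as a 2.0-fold higher number from compound 1 to compound 3 (0.30 log units; within the scatter). Compound 3 is therefore expected to give about 40 nM in this assay, within a range from 10 nM to 160 nM.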

Compound 3, inhibition constant: 82 nM
Compound 3: middle estimate off by 2.1-fold (0.31 log units), on the low side; measured number inside the range.
By their numbers in this assay, from the lowest: compounds 1 and 2 (each within the scatter of the next); then compound 3.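

Trifluoromethyl in place of cyclohexyl gives a 4.1-fold higher number from compound 1 to compound 3 (0.61 log units; beyond the scatter) in this assay, and this is the first step at this aromatic carbon that can be read beyond the scatter. The number therefore responds to the group on this carbon, though the step is modest, and the rest of the shared core stays the same across the pair, so the step belongs to this one swap. A six-membered ring of carbon leaves and a smaller group with no ring enters, yet nothing shown here explains why the number rises.

Going by these compounds, what remains open is how other groups would behave on the same aromatic carbon, such as a methoxy group, an amine or a tert-butyl group, and whether any of them would fall closer to cyclohexyl or to trifluoromethyl. For the compounds shown here, it is also open whether this swap would give a step of similar size on a different core, as this single pair is the only example of the change.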